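Shifting the methyl group on the phenyl ring

A few compounds are considered here, and "the series" means these few. Any claim that something is new, unique, unknown or untested is made for them only; others in the source may bear on it.

Measured compounds in an assay on isolated protein for agonist activity at Bile acid receptor (Homo sapiens), read by AlphaScreen, with a stated time of 30 min; a lower number here means that less compound is needed, a higher number that more compound is needed for the effect:
compound 1 `CCc1ccccc1-n1nc(C)c2c1NC(=O)[C@H](C)S[C@@H]2c1ccc(Oc2ccccc2)cc1` gives 1100 nM
compound 2 `Cc1cccc(-n2nc(C)c3c2NC(=O)[C@H](C)S[C@@H]3c2ccc(Oc3ccccc3)cc2)c1` gives 2400 nM

Within the data shown here, compound 2 stands highest of the two numbers measured so far; its nearest neighbour is compound 1, reached by the step of a 2.2-fold higher number from compound 1 to compound 2 (0.34 log units; beyond the scatter). Compound 3 `Cc1ccccc1-n1nc(C)c2c1NC(=O)[C@H](C)S[C@@H]2c1ccc(Oc2ccccc2)cc1` differs from compound 2 by 2-methylphenyl in place of 3-methylphenyl on an aromatic nitrogen. Among the measured compounds shown here, only one measured step bears on this change, the one from compound 1 to compound 2, where the 2-substituted phenyl ring gave the lower number. Since compound 3 returns to a 2-substituted phenyl ring, a modest step back toward the value of compound 1 is expected, a 1.8-fold lower number from compound 2 to compound 3 (0.27 log units; within the scatter). The estimate for compound 3 is therefore 1300 nM, within a range of 600 nM to 3000 nM.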

Compound 3, half-maximal effective concentration: 1300 nM
For compound 3 middle estimate and measured number coincide at the digits printed; the measured number falls inside the stated range.
By their numbers in this assay, from the lowest: compounds 1, 3 and 2 (each within the scatter of the next, the first and the last beyond it).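

In this assay, the change from 3-methylphenyl to 2-methylphenyl on the aromatic nitrogen gives a 1.8-fold lower number from compound 2 to compound 3 (0.27 log units; within the scatter), so these two isomers cannot be told apart. The change from 2-ethylphenyl to 2-methylphenyl gives a 1.2-fold higher number from compound 1 to compound 3 (0.07 log units; within the scatter), so shortening this chain by one carbon leaves no readable change either. Among these compounds, compound 3 thus lies within the scatter of both compound 1 and compound 2, and only the step between those two lies beyond it. As far as these compounds go, how an amine or a carboxylic acid on this phenyl ring would read in this assay remains open. No evidence is at hand to explain these numbers.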